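A hydroxy group enters beside three limit values

The source may hold more compounds than are shown below. What is called first, only, known or untested is meant among the compounds shown, and "the series" means these compounds.

Compound 3 `COc1ccc(CS(=O)(=O)/C=C/c2cc(OC)c(OC)c(OC)c2)cc1` is the reference point. In a functional assay on DU-145 cells (Homo sapiens) for antiproliferative activity, read by trypan blue exclusion (on this read-out lower numbers stand for stronger inhibition and higher numbers for weaker inhibition), compound 3 gives > 20000 nM, which is a limit of the assay rather than a number. Compound 1 `COc1ccc(CS(=O)(=O)/C=C/c2ccc(OC)c(OC)c2)cc1` gives > 20000 nM in this assay, again a limit. Compound 2 `COc1ccc(CS(=O)(=O)/C=C/c2cc(OC)cc(OC)c2)cc1` gives > 20000 nM in this assay, also a limit. The two steps that lead into compound 3, a step that the two limits leave unreadable from compound 1 to compound 3 and a step that the two limits leave unreadable from compound 2 to compound 3, therefore cannot be read in size, since all three values sit at the limit of > 20000 nM in this assay, at which 3 of the 3 values shown sit.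

Compound 4 `COc1ccc(CS(=O)(=O)/C=C/c2cc(OC)c(OC)c(OC)c2)cc1O` differs from compound 3 in one place: hydroxy in place of hydrogen on an aromatic carbon. Among the compounds with values here, no measured step involves a hydroxy group, and the only steps that reach compound 3 are the two unreadable ones, so the change from compound 3 to compound 4 rests on no read step at all. Compound 3 itself is known only as a limit, which leaves the direction of any step from it open in one direction and bounded in the other.

On this basis compound 4 is expected to give about 8000 nM in this assay, within a wide range from 500 nM to 40000 nM. The step this estimate implies, an at least 2.5-fold lower number from compound 3 to compound 4 (0.39 log units; beyond the scatter), is itself only an expectation.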

Compound 4, half-maximal inhibitory concentration: 5000 nM
For compound 4 the middle estimate is 1.6-fold (0.20 log units) above the measured one; measured number inside the range.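

In this assay, hydroxy in place of hydrogen, on the aromatic carbon that is ortho to a methoxy group and meta to a large group, gives an at least 4.0-fold lower number from compound 3 to compound 4 (0.60 log units; beyond the scatter). This is the first step among the compounds shown whose size can be read even in part, whereas the earlier steps, both methoxy in place of hydrogen, cannot be read, and it lies beyond the scatter; the printed size is a lower bound, so the full size of the change remains unknown. The 3-hydroxy-4-methoxyphenyl compound 4 is also the only one of the four shown that gives a number rather than a limit: the limit of > 20000 nM in this assay, at which 3 of the 4 values shown sit.

The compounds shown leave open whether this shift belongs to hydroxy itself or would also follow from another group on the same carbon, such as an amine, a fluorine atom or a carboxylic acid. They also leave open whether the same 3-hydroxy-4-methoxyphenyl change would have a similar effect on the core of compound 1 or compound 2, which carry fewer methoxy groups on the other ring.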